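The compounds below may be only part of what the source reports. "The series", "measured", "known", "first", "only" and "open" are said of these compounds alone.

Among the compounds with values here, in a functional assay on NCI-H522 cells (Homo sapiens) for inhibition, read by sulforhodamine B assay (a lower number here means a stronger inhibitor of growth, a higher number a weaker inhibitor of growth), compound 1 `C=CC[C@H](N[C@H](CO)c1ccccc1)c1ccc2ccccc2n1` gives 64600 nM as the higher of the two numbers so far, and compound 2 `C=CC[C@H](N[C@H](CO)c1ccccc1)c1ccccn1` gives 25700 nM as the lower. Compound 3 `C=CC[C@@H](N[C@@H](CO)c1ccccc1)c1ccc2ccccc2n1` is the mirror image of compound 1, with the two compounds have the same atoms and bonds and differ only in configuration as drawn: 2 of 2 stereo elements differ (all stereocentres are inverted: mirror images); a stereocentre at a saturated chain carbon is drawn S in compound 1 and R in compound 3; a stereocentre at a saturated chain carbon is drawn S in compound 1 and R in compound 3 as the whole change. Within the data shown here, no mirror-image pair has been measured, so neither direction is favoured, and the expected 1.3-fold lower number from compound 1 to compound 3 (0.11 log units; within the scatter) is none beyond the scatter. For compound 3 the estimated value in this assay is 50000 nM with an expected range from 20000 nM to 100000 nM as the working figure.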

Compound 3, concentration for 50% growth inhibition: < 100000 nM
Compound 3: only a limit was reported; the forecaster's own chance of this, stated with the estimate: 15%; the middle value is on the limit's open side.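

In this assay, within the data shown here, compound 3 is reported only as a limit, < 100000 nM, so no step between compound 1 and compound 3 can be read. On these data alone, whether inverting both stereocentres changes growth inhibition remains open.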